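Sulfamoyl for methylsulfonyl on the methylated core

The source may hold more compounds than are shown below. What is called first, only, known or untested is meant among the compounds shown, and "the series" means these compounds.

Measured compounds:
compound 1 `CS(=O)(=O)c1ccc(Nc2nccc(Nc3nc4ccc(F)cc4s3)n2)cc1`: 2080 nM
compound 2 `Cc1cnc(Nc2ccc(S(C)(=O)=O)cc2)nc1Nc1nc2ccc(F)cc2s1`: > 50000 nM, a limit of the assay, not a number

In a functional assay on MDA-MB-231 cells (Homo sapiens) for antiproliferative activity, read by MTT assay, with a stated time of 48 h (a lower number here means a stronger inhibitor, a higher number a weaker inhibitor), compound 1 gives 2080 nM. Compound 2 returns only > 50000 nM, which is the assay limit (the limit of > 50000 nM in this assay, at which 1 of the 2 values shown sits). Among the measured compounds shown here, the single measured step, an at least 24-fold higher number from compound 1 to compound 2 (1.38 log units; beyond the scatter), is large, and it places compound 2 at the limit with no number of its own.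

Compound 3 `Cc1cnc(Nc2ccc(S(N)(=O)=O)cc2)nc1Nc1nc2ccc(F)cc2s1` differs from compound 2 by amino in place of methyl on a sulfonyl sulfur; cut one bond further out, methylsulfonyl becomes sulfamoyl. For the measured compounds named here, no measured step touches the sulfonyl sulfur: the one step on record concerns the methyl on an aromatic carbon, which compound 2 and compound 3 both carry. The numbers therefore give no direction for this change. The expected step of a number no higher from compound 2 to compound 3 (the limit leaves the size open) is none beyond the scatter. Since compound 2 sits at the limit, compound 3 is expected most probably to return a limit as well. Compound 3 is estimated at 50000 nM, with a range of 15000 nM to 200000 nM.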

Compound 3, half-maximal inhibitory concentration: 7580 nM
The estimate for compound 3 lay 6.6-fold (0.82 log units) above the measured number, outside the stated range (below it).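

On the methylated core, the substituent on the sulfonyl sulfur proves able to move the result: in this assay, amino in place of methyl gives an at least 6.5-fold lower number from compound 2 to compound 3 (0.81 log units; beyond the scatter). The methyl on the aromatic carbon therefore does not by itself leave a compound without a measured number: compound 3 carries that methyl and still gives 7580 nM. The true size of the step stays unknown, since the value of compound 2 is a limit of the assay and not a number: the limit of > 50000 nM in this assay, at which 1 of the 3 values shown sits.

The compounds shown leave open how sulfamoyl behaves on the core of compound 1, with hydrogen in place of the aromatic methyl, and so whether the effects of the two changes simply add. They also leave open whether the gain depends on the amino group itself or would carry over to other groups on the sulfonyl sulfur, such as methylamino, dimethylamino or a hydroxyl.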